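A few compounds are considered here, and "the series" means these few. Any claim that something is new, unique, unknown or untested is made for them only; others in the source may bear on it.

Compound 2, `COc1cc(NC(C)CCCNC(=O)NNC(=O)Nc2ccc(Cl)cc2)c2ncccc2c1`, is the weaker of the two compounds measured here: in a functional assay on NCI-H460 cells (Homo sapiens) for inhibition, read by MTT assay, with a stated time of 72 h (a lower number here means a stronger inhibitor, a higher number a weaker inhibitor), compound 2 gives 63000 nM, the highest of the two numbers shown. Its nearest neighbour is compound 1, `COc1cc(NC(C)CCCNC(=O)NNC(=O)Nc2ccc(Br)cc2)c2ncccc2c1`, which in this assay gives 27000 nM. These two compounds differ only in one halogen, and the step is a 2.3-fold higher number from compound 1 to compound 2 (0.37 log units; beyond the scatter), a modest change that nonetheless lies beyond the scatter.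

Compound 3, `COc1cc(NC(C)CCCNC(=O)Nc2ccc(Br)cc2)c2ncccc2c1`, has not yet been measured. It differs from compound 2 in this way: 4-bromophenyl in place of ((4-chlorophenyl)carbamoyl)amino on an amide-type nitrogen. The bromo-for-chloro step from compound 1 to compound 2 bears on this only in part, since compound 3 brings a bromine back but also removes the whole urea-hydrazide segment that both measured compounds share. Going by the values given here, no measured step covers that larger change, so the direction of the shift in this assay cannot be read from the data; the only anchor is that bromine was the better halogen in compound 1.

The number for compound 3 is therefore expected to fall near the two measured values, with a wide range: 30000 nM (from 8000 nM to 120000 nM), which would mean an estimated step of a 2.1-fold lower number from compound 2 to compound 3 (0.32 log units; beyond the scatter).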

Compound 3, half-maximal inhibitory concentration: 30000 nM
The estimate for compound 3 equals the measured number at the digits printed; measured number inside the range.
By their numbers in this assay, from the lowest: compounds 1 and 3 (each within the scatter of the next); then compound 2.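

On the amide-type nitrogen, the ((4-bromophenyl)carbamoyl)amino group of compound 1 can give way to a plain 4-bromophenyl with bromine kept in place, and in this assay this is a 1.1-fold higher number from compound 1 to compound 3 (0.05 log units; within the scatter), so with bromine on both sides the whole urea-hydrazide segment can go without a difference beyond the scatter. The other new step, a 2.1-fold lower number from compound 2 to compound 3 (0.32 log units; beyond the scatter), changes the segment and the halogen at once, so on its own it cannot say which of the two matters; read beside the bromine pair, it fits the halogen rather than the segment, though three compounds are a thin base for that reading. No measurement here explains why the segment makes so little difference in these cells.

The compounds shown leave open what a 4-chlorophenyl placed directly on that nitrogen would give, which would test the halogen without the segment. They also leave open whether an unsubstituted phenyl, a 4-fluorophenyl, or a ring carrying an amine or a carboxylic acid would move the number in either direction.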